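The source may hold more compounds than are shown below. What is called first, only, known or untested is meant among the compounds shown, and "the series" means these compounds.

Working notes on the series, all read in a functional assay on MDA-MB-231 cells (Homo sapiens) for cytotoxicity, read by MTT assay, with a stated time of 48 h; on this read-out higher numbers stand for weaker inhibition and lower numbers for stronger inhibition. Compound 1 `Fc1ccc(C(CCCCOCc2ccc(Oc3ccc(Cl)cc3)cc2)c2ccc(F)cc2)cc1` gives > 20000 nM, which is a limit and not a number. Compound 2 `O=C(OCCCC(c1ccc(F)cc1)c1ccc(F)cc1)c1cc(Cl)c(OCc2ccccc2)c(Cl)c1` gives > 20000 nM, again a limit. Compound 3 `Nc1ccc(NC(=O)NCCCCC(c2ccc(F)cc2)c2ccc(F)cc2)cc1` gives > 20000 nM, also a limit. The whole set therefore rests on (the limit of > 20000 nM in this assay, at which 3 of the 3 values shown sit). Going by the values given here, no two measured compounds differ in one place, and no measured step is available to size a change.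

Compound 4 `O=C(NCCCCC(c1ccc(F)cc1)c1ccc(F)cc1)Nc1ccc(C(F)(F)F)cc1` differs from compound 3 by one change: trifluoromethyl in place of amino on an aromatic carbon. Trifluoromethyl stands in place of amino on an aromatic carbon, para to a large group. The expectation starts from compound 3 at > 20000 nM, a limit. A modest shift towards stronger inhibition is expected in this assay, and a result still at the limit remains quite possible. The expected step is an at least 1.2-fold lower number from compound 3 to compound 4 (0.09 log units; that floor lies within the scatter). The estimate for compound 4 is 16000 nM, with an expected range of 6000 nM to 30000 nM.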

Compound 4, half-maximal inhibitory concentration: 2780 nM
The estimate for compound 4 lay 5.8-fold (0.76 log units) above the measured number, outside the stated range (below it).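

In this assay, replacing amino with trifluoromethyl on an aromatic carbon, para to a large group, gives an at least 7.1-fold lower number from compound 3 to compound 4 (0.85 log units; beyond the scatter). The value of compound 3, > 20000 nM, is a limit and not a number, so this step gives only a floor for the size of the change. Compound 4 is the one compound shown that reads clear of the limit marking the rest of the set: the limit of > 20000 nM in this assay, at which 3 of the 4 values shown sit.

On these data alone, whether the gain comes from trifluoromethyl itself or from the loss of amino stays open; a hydrogen, a chlorine or a nitrile on the same aromatic carbon would separate the two. Also open, as far as these compounds go, is how far the reading of compound 4 depends on its chain, which a shorter or longer chain would test.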